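A few compounds are considered here, and "the series" means these few. Any claim that something is new, unique, unknown or untested is made for them only; others in the source may bear on it.

The measured compounds:
Compound 1 `CN(C)C(=O)c1cc2cnc(Nc3ccc(NC(=O)C4(C(=O)Nc5ccc(Cl)cc5)CC4)cc3)nc2n1C1CCCC1`, which in a functional assay on NCI-H1299 cells (Homo sapiens) for inhibition, read by CCK-8 assay, with a stated time of 72 h, tested at 10 uM (a higher number here means more inhibition of growth at the concentration tested, a lower number less inhibition of growth), gives 88.6%.
Compound 2 `CN(C)C(=O)c1cc2cnc(Nc3ccc(NC(=O)C4(C(=O)Nc5cccc(Cl)c5)CC4)cc3)nc2n1C1CCCC1`, which in this assay gives 84.1%.
Compound 3 `Cc1ccc(NC(=O)C2(C(=O)Nc3ccc(Nc4ncc5cc(C(=O)N(C)C)n(C6CCCC6)c5n4)cc3)CC2)cc1`, which in this assay gives 84.5%.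

Compound 1 holds the highest of the three numbers, but both steps away from it, a number 4.1 percentage points lower from compound 1 to compound 3 (within the scatter) and a number 4.5 percentage points lower from compound 1 to compound 2 (within the scatter), fall within the scatter, so the three compounds cannot be put in order and none can be called the strongest.

Compound 4 `CN(C)C(=O)c1cc2cnc(Nc3ccc(NC(=O)C4(C(=O)Nc5ccccc5)CC4)cc3)nc2n1C1CCCC1` differs from compound 1 by hydrogen in place of chloro on an aromatic carbon. The chloro leaves, a hydrogen enters, on an aromatic carbon of a six-membered aromatic ring of carbon only; read one bond further out, 4-chlorophenyl becomes phenyl.

Within the data shown here, two measured steps bear on this. The step of a number 4.1 percentage points lower from compound 1 to compound 3 (within the scatter) also removes the chloro from that aromatic carbon, putting methyl in its place, and stays within the scatter. The step of a number 4.5 percentage points lower from compound 1 to compound 2 (within the scatter) moves the chloro to another position and likewise stays within the scatter, as does a number 0.4 percentage points higher from compound 2 to compound 3 (within the scatter). Nothing measured on this core shows the anilide substituent moving the number beyond the scatter. For compound 4 the expected step is therefore a number 3.6 percentage points lower from compound 1 to compound 4 (within the scatter), none beyond the scatter. Compound 4 is estimated at 85%, in a range from 73% to 94%.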

Compound 4, percent growth inhibition at one concentration: 90.5%
The estimate for compound 4 lay 5.5 percentage points below the measured number; measured number inside the range.
By their numbers in this assay, from the lowest: compounds 2, 3, 1 and 4 (each within the scatter of the next).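

Removing the substituent altogether gives the first unsubstituted phenyl in the set, and the number in this assay stays within the scatter of all three substituted anilides (a number 1.9 percentage points higher from compound 1 to compound 4 (within the scatter); a number 6 percentage points higher from compound 3 to compound 4 (within the scatter); a number 6.4 percentage points higher from compound 2 to compound 4 (within the scatter)). The earlier compounds only exchanged one substituent for another or moved the chloro, so they could not show whether a substituent on this ring was needed at all; among these four compounds, the number does not depend on one, and no compound goes against this. No measurement is available that would explain this flat result.

The compounds shown leave open whether a group of a different kind on this aromatic carbon, such as a carboxylic acid, an amine or a longer alkyl chain, would move the number beyond the scatter, since hydrogen, chloro and methyl are the only substituents compared here. They also leave open whether these four compounds would separate at a lower concentration, as each was read at a single concentration and none can be ranked above another.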